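Swapping the chlorinated benzyl of compound 1 for a difluorinated one

A few compounds are considered here, and "the series" means these few. Any claim that something is new, unique, unknown or untested is made for them only; others in the source may bear on it.

Measured so far:
compound 1 `Cc1ccc(S(=O)(=O)N(Cc2cn(Cc3ccccc3Cl)nn2)Cc2cn(S(=O)(=O)c3ccc(C)cc3)c3ccccc23)cc1`: -4.8%
compound 2 `O=C(N(Cc1ccc(F)cc1)Cc1cccc(F)c1F)C(F)(F)F`: -39.8%
compound 3 `Cc1ccc(S(=O)(=O)N(Cc2cn(Cc3ccc(F)cc3F)nn2)Cc2c(C)c3ccccc3n2S(=O)(=O)c2ccc(C)cc2)cc1`: -22%

In a functional assay on 3T3-L1 cells (Mus musculus) for inhibition, with a stated time of 20 min, tested at 20 uM (a higher number here means more inhibition at the concentration tested (going by the name of the read-out), a lower number less inhibition), compound 1 gives -4.8%, the highest of the three numbers. Compound 3 is nearest, lower by a gap beyond the scatter; compound 2 is furthest, lower still. Compound 4 `Cc1ccc(S(=O)(=O)N(Cc2cn(Cc3cccc(F)c3F)nn2)Cc2cn(S(=O)(=O)c3ccc(C)cc3)c3ccccc23)cc1` is not yet measured. It differs from compound 1 in one place: 2,3-difluorophenyl in place of 2-chlorophenyl on a saturated chain carbon bound to an aromatic nitrogen. Among the compounds with values here, no pair of measured compounds differs in one place only, so no step of this kind has been seen, and compound 2 and compound 3 differ from compound 1 in more than the benzyl arm. The expected step is a number 7.2 percentage points lower from compound 1 to compound 4 (within the scatter), small and downward if anything, not clearly beyond the scatter. Compound 4 is estimated at -12%, within -32% to 8%.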

Compound 4, a percentage reported as inhibition, at one concentration (the size of the read-out at that concentration, not a potency): 71.5%
The estimate for compound 4 lay 83.5 percentage points below the measured number, outside the stated range (above it).
By their numbers in this assay, from the lowest: compound 2; then compound 3; then compound 1; then compound 4.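

Within the data shown here, on a saturated chain carbon bound to an aromatic nitrogen, 2,3-difluorophenyl in place of 2-chlorophenyl gives the first single-place step in this assay, with a number 76.3 percentage points higher from compound 1 to compound 4 (beyond the scatter) as a large change beyond the scatter. This position is therefore not silent: with the rest of compound 1 unchanged, this one change takes a negative reading to a positive one. Nothing measured here accounts for the size of the step.

This single pair cannot separate losing the chlorine from gaining the fluorines. Also open, from the compounds shown here alone, is whether inhibition survives replacing the halogenated phenyl with a carboxylic acid or an amine.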